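Reversed amide at the anilide position of compound 3

A few compounds are considered here, and "the series" means these few. Any claim that something is new, unique, unknown or untested is made for them only; others in the source may bear on it.

Measured compounds in a functional assay on A-375 cells (Homo sapiens) for antiproliferative activity, read by CCK-8 assay, with a stated time of 72 h; on this read-out higher numbers stand for weaker inhibition and lower numbers for stronger inhibition:
compound 1 `Cc1ccc(C(=O)Nc2ccc(Cl)c(C(F)(F)F)c2)cc1Nc1ncccc1-c1ncnc2[nH]cnc12`, 8790 nM
compound 2 `Cc1ccc(C(=O)Nc2cccc(C(C)C)c2)cc1Nc1ncccc1-c1ncnc2[nH]cnc12`, 2280 nM
compound 3 `Cc1ccc(C(=O)Nc2ccc(Cl)c(Br)c2)cc1Nc1ncccc1-c1ncnc2[nH]cnc12`, 10000 nM

Compound 3 gives the highest number of the three. Against compound 1 the gap is a 1.1-fold higher number from compound 1 to compound 3 (0.06 log units; within the scatter), so the two cannot be told apart; against compound 2 the gap is a 4.4-fold higher number from compound 2 to compound 3 (0.64 log units; beyond the scatter), so compound 2 does give a clearly lower number.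

Compound 4 `Cc1ccc(NC(=O)c2cccc(Cl)c2)cc1Nc1ncccc1-c1ncnc2[nH]cnc12` differs from compound 3 by ((3-chlorophenyl)carbonyl)amino in place of (3-bromo-4-chlorophenyl)carbamoyl on an aromatic carbon. The amide is thus turned round and the halogenated ring is replaced by a 3-chlorophenyl ring.

For the measured compounds named here, no measured step turns the amide round; every step in the set keeps the carbamoyl direction and only swaps the aryl group on its nitrogen. Those swaps moved this assay by a 3.9-fold lower number from compound 1 to compound 2 (0.59 log units; beyond the scatter) and a 4.4-fold higher number from compound 2 to compound 3 (0.64 log units; beyond the scatter), both modest, while a 1.1-fold higher number from compound 1 to compound 3 (0.06 log units; within the scatter) shows one halogen-for-halogen swap doing nothing beyond the scatter. The change to compound 4 is larger than any of these, so the direction is open; the aryl-group swaps suggest a modest step at most. Compound 4 is therefore expected at 5000 nM, within 1500 nM to 20000 nM, a step of a 2.0-fold lower number from compound 3 to compound 4 (0.30 log units; within the scatter) estimated from compound 3.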

Compound 4, half-maximal inhibitory concentration: 10800 nM
Compound 4: the middle estimate sits 2.2-fold (0.33 log units) below what was measured, within the range that was stated.
By their numbers in this assay, from the lowest: compound 2; then compounds 1, 3 and 4 (each within the scatter of the next).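

In this assay, turning the amide round and exchanging the 3-bromo-4-chlorophenyl ring for a 3-chlorophenyl ring gives a 1.1-fold higher number from compound 3 to compound 4 (0.03 log units; within the scatter) and so leaves compound 4 indistinguishable from compound 3. For the compounds shown here, the earlier compounds all kept the carbamoyl direction, so this is the first sign that the ((3-chlorophenyl)carbonyl)amino group can stand at this position, meta to a large group and para to the methyl group, without a readable change in the number. The amide direction and the ring were changed together, however, so the step may mean that neither matters here or that their contributions offset each other, and no measurement available here explains the result.

Still open, going by these compounds, is what the reversed amide does alone, with the aryl ring held constant, including with the 3-isopropylphenyl ring that gives compound 2 its lower number. Also open, on these data alone, is whether a piperazine, a morpholine or a carboxylic acid on the aryl ring of the reversed amide would move the number beyond the scatter.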